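A few compounds are considered here, and "the series" means these few. Any claim that something is new, unique, unknown or untested is made for them only; others in the source may bear on it.

Measured so far in a functional assay on a cell-free system (plasma, Homo sapiens) for inhibition, with Plasma (Rattus norvegicus) as the target; a higher number here means a weaker inhibitor, a lower number a stronger inhibitor:

- compound 1, `O=C(O)CC(NC(=O)c1cccc(C(=O)Nc2ccc3c(c2)CNCC3)c1)c1ccccc1`: 25 nM
- compound 2, `COc1ccc(C(CC(=O)O)NC(=O)c2cccc(C(=O)Nc3ccc4c(c3)CNCC4)c2)cc1`: 17 nM
- compound 3, `O=C(O)CC(NC(=O)c1cc(C(=O)Nc2ccc3c(c2)CNCC3)cc([N+](=O)[O-])c1)c1ccccc1`: 710 nM

Compound 1 and compound 2 share a core and differ by one change only:

methoxy in place of hydrogen on an aromatic carbon

This change gave a 1.5-fold lower number from compound 1 to compound 2 (0.17 log units; within the scatter), a step that stays within the scatter of repeated measurements, so the two values are treated as indistinguishable here.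

Compound 3 has the core of compound 1 with one further change:

nitro in place of hydrogen on an aromatic carbon

That change gave a 28-fold higher number from compound 1 to compound 3 (1.45 log units; beyond the scatter), a large step that lies well beyond the scatter.

Compound 4, `COc1ccc(C(CC(=O)O)NC(=O)c2cc(C(=O)Nc3ccc4c(c3)CNCC4)cc([N+](=O)[O-])c2)cc1`, is not yet measured in this assay. Relative to compound 3 it carries the following change:

methoxy in place of hydrogen on an aromatic carbon

The place of this change is described in the same words as the change from compound 1 to compound 2, so it is taken as the same change, now made on the core of compound 3 rather than on the core of compound 1. Among the measured compounds shown here, the only evidence on how this change acts is the single step of a 1.5-fold lower number from compound 1 to compound 2 (0.17 log units; within the scatter), which hardly moved the value. On that basis the expected step from compound 3 to compound 4 in this assay is a 1.5-fold lower number from compound 3 to compound 4 (0.18 log units; within the scatter), placed beside the earlier one and likewise expected to stay within the scatter. Compound 4 is therefore estimated at 470 nM, with the range 200 nM to 1100 nM, because the starting value of compound 3 is 710 nM and there is no indication from compounds 1 and 2 that the change would alter it much.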

Compound 4, half-maximal inhibitory concentration: 450 nM
Beside the measured number, compound 4's estimate is 1.0-fold (0.02 log units) above it, and the stated range covers the measured number.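

In this assay, phenyl to 4-methoxyphenyl on the nitro-bearing core gives a 1.6-fold lower number from compound 3 to compound 4 (0.20 log units; within the scatter), which matches the step seen on the core without nitro: the same change on two cores in this assay, a 1.5-fold lower number (0.17 log units; within the scatter) from compound 1 to compound 2 and a 1.6-fold lower number (0.20 log units; within the scatter) from compound 3 to compound 4, 1.1-fold (0.03 log units) apart, within the scatter of two such steps

The nitro change, read on the pair carrying the 4-methoxyphenyl group, gives a 26-fold higher number from compound 2 to compound 4 (1.42 log units; beyond the scatter), and this large step also carries over: the same change on two cores in this assay, a 28-fold higher number (1.45 log units; beyond the scatter) from compound 1 to compound 3 and a 26-fold higher number (1.42 log units; beyond the scatter) from compound 2 to compound 4, 1.1-fold (0.03 log units) apart, within the scatter of two such steps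

Across these four compounds the two changes therefore combine without a measurable interaction, but this rests on only two cores for each change, and since both methoxy steps lie within the scatter, the carry-over shown for methoxy is that of a step too small to distinguish from no change, so only the nitro step demonstrates the transfer of a real shift.

The compounds shown leave open whether another group in place of the nitro, such as an amine or a nitrile, would bring a step of similar size, or whether that step belongs to nitro alone. They also leave open whether a group other than methoxy on the phenyl ring, such as chlorine or hydroxyl, would move the value beyond the scatter and, if so, whether such a step would carry between the two cores as the nitro step does.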